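The compounds below may be only part of what the source reports. "The series", "measured", "known", "first", "only" and "open" are said of these compounds alone.

Of the compounds shown here, three have a number so far. Compound 1 `COc1cc(C(=O)/C=C\Nc2ccc(-c3nc4cc(OC)c(OC)c(OC)c4s3)cc2)c(Br)c(OC)c1OC` gives 15600 nM in a functional assay on MDA-MB-231 cells (Homo sapiens) for antiproliferative activity, read by sulforhodamine B assay, with a stated time of 48 h; on this read-out lower numbers stand for stronger inhibition and higher numbers for weaker inhibition. Compound 2 `COc1cc(OC)c2sc(-c3ccc(N/C=C\C(=O)c4ccc(OC)c(F)c4)c(C)c3)nc2c1` gives 13300 nM in this assay, and compound 3 `COc1ccc2nc(-c3ccc(N/C=C\C(=O)c4ccc(OC)c(F)c4)cc3)sc2c1` gives 1100 nM in this assay. Among these three numbers compound 2 stands second highest; the number of compound 1 lies within the usual scatter of it, so the two cannot be told apart, while the number of compound 3 lies far lower, a gap that is well beyond the scatter.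

Compound 4 `COc1cc(OC)c2sc(-c3ccc(N/C=C\C(=O)c4ccc(OC)c([N+](=O)[O-])c4)c(C)c3)nc2c1` has not yet been measured in this assay. It differs from compound 2 in one place: nitro in place of fluoro on an aromatic carbon. The change sits on an aromatic carbon of a six-membered aromatic ring of carbon only, ortho to a methoxy group and meta to a large group; read one bond further out, 3-fluoro-4-methoxyphenyl becomes 4-methoxy-3-nitrophenyl.

Going by the values given here, no measured pair in this set carries the same change, so there is no step to lean on, and its direction cannot be read from the numbers of compounds 1, 2 and 3. The step from compound 2 to compound 4 is therefore expected to be small, most likely within the scatter, as a 1.3-fold lower number from compound 2 to compound 4 (0.12 log units; within the scatter). Compound 4 is estimated to give 10000 nM in this assay, with a range from 3000 nM to 35000 nM.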

Compound 4, half-maximal inhibitory concentration: 10800 nM
Compound 4: middle estimate off by 1.1-fold (0.03 log units), on the low side; measured number inside the range.
By their numbers in this assay, from the lowest: compound 3; then compounds 4, 2 and 1 (each within the scatter of the next).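

Going by these compounds alone, replacing fluoro with nitro on this aromatic carbon, ortho to a methoxy group and meta to a large group, provides the first comparison that differs in only one place. In this assay it gives a 1.2-fold lower number from compound 2 to compound 4 (0.09 log units; within the scatter), so the exchange of fluoro, with 1 heavy atom and 0 hydrogen-bond acceptors, for nitro, with 3 heavy atoms and 2 hydrogen-bond acceptors, leaves no difference that can be told from the scatter at this position. No independent measurement is available to account for this outcome.

This single pair does not show how an amine, a carboxylic acid or a longer alkoxy chain on the same aromatic carbon would read, nor what a plain hydrogen there would give, so the tolerance seen here cannot be extended beyond fluoro and nitro. Within the data shown here, it also remains open whether the same exchange would read alike on the core of compound 3, since the step so far rests on the core shared by compound 2 and compound 4 alone.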